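A Second Chloro on Compound 3

The source may hold more compounds than are shown below. What is called first, only, known or untested is meant among the compounds shown, and "the series" means these compounds.

Of the compounds shown here, three sharing one core have been measured in an in vitro ADME assay on microsomes from liver (Mus musculus) for pharmacokinetics, read by LC-MS, with a stated time of 10 min, tested at 1 uM; on this read-out higher numbers stand for fast clearance and lower numbers for slow clearance. Compound 1 `CN1C[C@H](C(=O)Nc2ccc(F)cc2)[C@@H](c2ccc(/C=C/C(=O)Nc3ccccc3N)cc2)C1` gives 34 mL/min/kg, compound 2 `CC(C)c1ccc(NC(=O)[C@H]2CN(C)C[C@@H]2c2ccc(/C=C/C(=O)Nc3ccccc3N)cc2)cc1` gives 54 mL/min/kg, and compound 3 `CN1C[C@H](C(=O)Nc2cccc(Cl)c2)[C@@H](c2ccc(/C=C/C(=O)Nc3ccccc3N)cc2)C1` gives 58 mL/min/kg. Compound 3 therefore stands level with the other two, since its numbers differ from theirs only by the ordinary noise of repeat measurements: a 1.7-fold higher number from compound 1 to compound 3 (0.23 log units; within the scatter), and a 1.1-fold higher number from compound 2 to compound 3 (0.03 log units; within the scatter).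

The next compound, compound 4 `CN1C[C@H](C(=O)Nc2ccc(Cl)c(Cl)c2)[C@@H](c2ccc(/C=C/C(=O)Nc3ccccc3N)cc2)C1`, differs from compound 3 in one place: chloro in place of hydrogen on an aromatic carbon. In words, this is chloro in place of hydrogen on an aromatic carbon, which turns 3-chlorophenyl into 3,4-dichlorophenyl.

For the measured compounds named here, no measured pair shows this exact change, so the evidence is indirect. The nearest guides are the swaps of the aromatic group on the amide-type nitrogen. Those two steps to compound 3 stayed within the scatter, and so did the isopropyl in place of fluoro step, a 1.6-fold higher number from compound 1 to compound 2 (0.20 log units; within the scatter). So far, then, changes on this group have not moved this assay beyond the scatter, and they suggest no direction. The expected change is a 1.1-fold lower number from compound 3 to compound 4 (0.02 log units; within the scatter), so no step beyond the scatter is anticipated. For compound 4 the estimated value is 55 mL/min/kg, with an expected range from 30 mL/min/kg to 100 mL/min/kg.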

Compound 4, clearance: 36 mL/min/kg
Compound 4: the middle estimate sits 1.5-fold (0.18 log units) above what was measured; the range from low to high includes it.
By their numbers in this assay, from the lowest: compounds 1, 4, 2 and 3 (each within the scatter of the next).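

Placing a chloro on this aromatic carbon, ortho to a chloro group and para to a large group, gives a 1.6-fold lower number from compound 3 to compound 4 (0.21 log units; within the scatter) in this assay, so this single added atom, a smaller change than the earlier swaps of the whole aromatic group, also stays within the usual scatter of repeat measurements. The 3,4-dichlorophenyl group cannot be told apart from the other two groups tested against it, with a 1.5-fold lower number from compound 2 to compound 4 (0.18 log units; within the scatter) for the 4-isopropylphenyl comparison and a 1.1-fold higher number from compound 1 to compound 4 (0.02 log units; within the scatter) for the 4-fluorophenyl comparison, so all four compounds now stand level and this aromatic group has shown no clear handle on the read-out. No supporting measurement is available that could explain where any of these numbers fall.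

From the compounds shown here alone, every group compared so far on this ring is a halogen or a small alkyl group, so it remains open whether an amine, a carboxylic acid or a methoxy group at the same carbon would give a step beyond the scatter. All four compounds also keep the rest of the structure unchanged, which leaves open whether a change on the shared core, such as a longer chain in place of its methyl group, would matter more.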